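This account rests on a few compounds, and the source may have more. Where it says the series, first, only, none or still open, it means among the compounds named here.

In an ADME assay on microsomes from liver (Homo sapiens) for metabolic stability, read by LC-MS, with NADPH named in the record, with a stated time of 60 min, tested at 1 uM, in the absence of a further agent (on this read-out higher numbers stand for a more stable compound and lower numbers for a less stable compound), compound 1 (`COc1ccc(-c2c(C)nc3c(N4CC[C@@H](NC(C)=O)C4)cc(C)nn23)cc1OC`) stands at > 95% as a limit of the assay, not a number. Compound 2 (`COc1ccc(-c2c(C)sc3c(N4CC[C@@H](NC(C)=O)C4)nc(C)nc23)cc1OC`) gives > 95% as a limit. Compound 3 (`COc1cc(-c2c(C)nc3c(N4CC[C@@H](NC(C)=O)C4)cc(C)nn23)cc(OC)c1OC`) gives > 95% as a limit. The series thus shows the limit of > 95% in this assay, at which 3 of the 3 values shown sit, and no number. Among the compounds with values here, the one measured step (a step that the two limits leave unreadable from compound 1 to compound 3) is methoxy in place of hydrogen on an aromatic carbon. Compound 4 (`CC(=O)N[C@@H]1CCN(c2cc(C)nn3c(-c4ccc(C(F)(F)F)cc4)c(C)nc23)C1`) carries 4-(trifluoromethyl)phenyl in place of 3,4-dimethoxyphenyl on an aromatic carbon. Within the data shown here, no measured step removes a methoxy group, so no size carries over. From compound 1 at > 95% as a limit, nothing beyond the scatter is expected, and any shift is expected downward. The expected move is a number at least 3 percentage points lower from compound 1 to compound 4 (that floor lies within the scatter) in this assay. Compound 4 is estimated at 92% within 80% to 100% on this reasoning.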

Compound 4, percent of the compound remaining: > 95%
Compound 4 was reported as a limit; the forecaster's own chance of this, stated with the estimate: 50%; at least 3 percentage points between middle value and limit.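

The step from compound 1 to compound 4 cannot be read, as both values are limits in this assay. The compounds shown leave open how far their stability differs, as all values share one limit: the limit of > 95% in this assay, at which 4 of the 4 values shown sit.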